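Adding a 2-hydroxyethyl branch to compound 2

The source may report more compounds than this note shows. Statements on the series, on what has been measured and on what is new or still open speak of the compounds shown alone.

- Compound 1 `CCn1c(C(=O)N[C@@H](CC(=O)OC)C(=O)OC)ccc1C(CC)(CC)c1ccc(OCS(=O)(=O)c2ccccc2)c(C)c1` measured at 6490 nM
- Compound 2 `CCn1c(C(=O)NCCO)ccc1C(CC)(CC)c1ccc(OCS(=O)(=O)c2ccccc2)c(C)c1` measured at 17700 nM
- Compound 3 `CCn1c(C(=O)N[C@H](CO)C(C)C)ccc1C(CC)(CC)c1ccc(OCS(=O)(=O)c2ccccc2)c(C)c1` measured at 7300 nM

In a functional assay on PC-3 cells (Homo sapiens) for antiproliferative activity, read by MTT assay, with a stated time of 24 h (on this read-out lower numbers stand for stronger inhibition and higher numbers for weaker inhibition), compound 2 gives 17700 nM as the highest of the three numbers, and its steps to both other compounds lie beyond the scatter. Compound 4 `CCn1c(C(=O)N[C@@H](CO)CCO)ccc1C(CC)(CC)c1ccc(OCS(=O)(=O)c2ccccc2)c(C)c1` keeps the shared core and differs from compound 2 in one place: 2-hydroxyethyl in place of hydrogen on a saturated chain carbon bound to an amide-type nitrogen and a saturated chain carbon. Its side chain thus reads 3-hydroxy-1-(hydroxymethyl)propyl instead of 2-hydroxyethyl.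

Among the compounds with values here, three measured steps bear on this change. The closest is a 2.4-fold lower number from compound 2 to compound 3 (0.38 log units; beyond the scatter), where isopropyl enters at the same carbon. Compound 1 also carries a larger group in place of 2-hydroxyethyl, and the comparison gives a 2.7-fold higher number from compound 1 to compound 2 (0.44 log units; beyond the scatter), which read backwards again favours the larger group. The two larger groups differ widely, yet the step is only a 1.1-fold higher number from compound 1 to compound 3 (0.05 log units; within the scatter). Within the data shown here, no measured compound carries the new group itself, so this remains an inference from two different groups.

A modest step towards a lower number is therefore expected in this assay. The estimated step is a 2.2-fold lower number from compound 2 to compound 4 (0.34 log units; beyond the scatter) as the central expectation. Compound 4 is expected at 8000 nM, with an estimated range from 4000 nM to 16000 nM.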

Compound 4, half-maximal inhibitory concentration: 14100 nM
Beside the measured number, compound 4's estimate is 1.8-fold (0.25 log units) below it; the range from low to high includes it.
By their numbers in this assay, from the lowest: compounds 1, 3, 4 and 2 (each within the scatter of the next, the first and the last beyond it).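

In this assay, a substituent on this saturated chain carbon bound to an amide-type nitrogen does not by itself separate a compound from compound 2: 2-hydroxyethyl gives a 1.3-fold lower number from compound 2 to compound 4 (0.10 log units; within the scatter), whereas isopropyl at the same carbon gives a 2.4-fold lower number from compound 2 to compound 3 (0.38 log units; beyond the scatter). The new side chain still cannot be told apart from the isopropyl-bearing one, with a 1.9-fold higher number from compound 3 to compound 4 (0.29 log units; within the scatter), but it does fall short of the side chain with the two methoxycarbonyl groups, with a 2.2-fold higher number from compound 1 to compound 4 (0.34 log units; beyond the scatter), so the earlier impression that larger groups on this nitrogen give similar numbers does not extend cleanly to 3-hydroxy-1-(hydroxymethyl)propyl. No supporting measurement is available here to explain why these groups behave as they do.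

The compounds shown leave open whether the hydroxyl at the end of the 2-hydroxyethyl group matters at this carbon, a question that a plain ethyl group or a 2-aminoethyl group in the same place would address. They also leave open how a carboxylic acid on this side chain would compare with the methyl esters of compound 1.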